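Dichloro-to-monochloro change on a benzyl-substituted bicyclic core

The source may report more compounds than this note shows. Statements on the series, on what has been measured and on what is new or still open speak of the compounds shown alone.

Measured in a functional assay on SF-295 cells (Homo sapiens) for cytotoxicity, read by sulforhodamine B assay, with a stated time of 48 h; on this read-out higher numbers stand for weaker inhibition of growth and lower numbers for stronger inhibition of growth:
compound 1 `ClCc1ccccc1Cn1cnc2c(Cl)nc(Cl)nc21` gives 1900 nM
compound 2 `ClCc1ccccc1Cn1cnc2c(Cl)ncnc21` gives 10500 nM
compound 3 `ClCc1ccc(Cn2cnc3nc(Cl)nc(Cl)c32)cc1` gives 1810 nM

Compound 3 and compound 1 carry the same atoms joined differently; the difference between the two cores is not broken down here. Their values in this assay lie within the usual scatter of each other, so no order is drawn between them.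

From compound 1 to compound 2 one change is made, (hydrogen in place of chloro on an aromatic carbon). It gives a 5.5-fold higher number from compound 1 to compound 2 (0.74 log units; beyond the scatter), a step beyond the scatter.

Compound 4 `ClCc1ccc(Cn2cnc3ncnc(Cl)c32)cc1` is not yet measured. It differs from compound 3 by the same change, (hydrogen in place of chloro on an aromatic carbon), made on the core of compound 3 rather than that of compound 1. With one prior example, the step is read as a single-case guide rather than a pattern.

For compound 4 in this assay the expected step is a 5.5-fold higher number from compound 3 to compound 4 (0.74 log units; beyond the scatter), set beside the measured step from compound 1 to compound 2, because compound 3 starts from 1810 nM. The estimate for compound 4 is 10000 nM, expected within 4000 nM to 25000 nM.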

Compound 4, concentration for 50% growth inhibition: 2040 nM
Estimate against measurement, compound 4: 4.9-fold (0.69 log units) above; the measured number lies below the stated range.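

In this assay, within the data shown here, hydrogen in place of chloro on an aromatic carbon gives a 1.1-fold higher number from compound 3 to compound 4 (0.05 log units; within the scatter), so on the core of compound 3 this change produces no step that can be told from the scatter. The change therefore does not carry over in size from the core of compound 1 to the core of compound 3: the same change on two cores in this assay, a 5.5-fold higher number (0.74 log units; beyond the scatter) from compound 1 to compound 2 and a 1.1-fold higher number (0.05 log units; within the scatter) from compound 3 to compound 4, 4.9-fold (0.69 log units) apart, beyond the scatter of two such steps

These two pairs show that the same replacement can give different steps on the two cores, but they do not show which structural difference of the cores accounts for this or how the change would behave on any further core.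

The compounds shown leave open whether the same difference of the two cores would appear if an amine or a methoxy group, rather than hydrogen, took the place of that chloro group. Also open, as far as these compounds go, is whether it would persist with a hydroxymethyl group on the benzyl ring in place of the chloromethyl group.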